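The source may hold more compounds than are shown below. What is called first, only, known or untested is meant among the compounds shown, and "the series" means these compounds.

Three compounds share one core and differ only in the group carried on the saturated chain bound to the sulfur. Compound 1 `O=C1CCCC(CSc2nc(-c3ccccc3)c(-c3ccccc3)[nH]2)O1` carries a six-membered non-aromatic ring with one hetero atom, and in an assay on microsomes from liver for inhibition of sterol O-acyltransferase 1 (Rattus norvegicus) (on this read-out higher numbers stand for weaker inhibition and lower numbers for stronger inhibition), compound 1 gives 740 nM. Compound 2 `O=C1CCC(CSc2nc(-c3ccccc3)c(-c3ccccc3)[nH]2)N1` carries a five-membered non-aromatic ring in its place, and in this assay compound 2 gives 360 nM, which is a 2.1-fold lower number from compound 1 to compound 2 (0.31 log units; beyond the scatter). Compound 3 `c1ccc(-c2nc(SCCC3OCCCO3)[nH]c2-c2ccccc2)cc1` carries a six-membered non-aromatic ring with two hetero atoms; in this assay compound 3 gives 730 nM. That places compound 3 second highest of the three: the difference is a 1.0-fold lower number from compound 1 to compound 3 (0.01 log units; within the scatter), while a 2.0-fold higher number from compound 2 to compound 3 (0.31 log units; beyond the scatter).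

Compound 4 `CCOC(CCSc1nc(-c2ccccc2)c(-c2ccccc2)[nH]1)OCC` has not been measured in this assay. Its change from compound 3 is a group of 7 heavy atoms (5 carbon, 2 oxygen; no ring) in place of a group of 6 heavy atoms (4 carbon, 2 oxygen; one six-membered non-aromatic ring with 2 hetero atoms), on a saturated chain carbon, two bonds along the chain from a sulfur: the ring opens into a diethoxymethyl group. Among the compounds with values here, no measured step opens a ring; the closest comparison, between compound 1 and compound 3, exchanged one six-membered ring for another and stayed within the scatter, and the two steps touching compound 2 were modest. Compound 4 is therefore expected to show a step of a 1.0-fold lower number from compound 3 to compound 4 (0.02 log units; within the scatter), one that need not exceed the scatter. The estimate for compound 4 in this assay is 700 nM, with a range from 300 nM to 1600 nM.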

Compound 4, half-maximal inhibitory concentration: 69 nM
Estimate against measurement, compound 4: 10-fold (1.01 log units) above; measured number below the stated range.
By their numbers in this assay, from the lowest: compound 4; then compound 2; then compounds 3 and 1 (each within the scatter of the next).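

In this assay, within the data shown here, opening the ring of compound 3 into a diethoxymethyl group gives the first large step at this position (an 11-fold lower number from compound 3 to compound 4 (1.02 log units; beyond the scatter)), even though the two groups have the same hydrogen-bond donor and acceptor counts and the same oxygen count. Compound 4 also stands apart from the other two ring-bearing compounds (an 11-fold lower number from compound 1 to compound 4 (1.03 log units; beyond the scatter) and a 5.2-fold lower number from compound 2 to compound 4 (0.72 log units; beyond the scatter)), so it is the strongest inhibitor of the four, with every step to it beyond the scatter. Among these compounds, the earlier ring-for-ring exchanges ranged only from no readable change to a modest step, whereas these four compounds show that the one group without a ring gives the lowest number, and the shared oxygen count of compound 3 and compound 4 does not by itself set the value.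

On these data alone, whether the low number depends on the ethyl ends of the group stays open, and a dimethoxymethyl group, a dipropoxymethyl group or an amine in place of one oxygen would each test a different part of it. Nothing available here accounts for the size of this step.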